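The compounds below may be only part of what the source reports. "The series", "measured", "known", "first", "only" and "open" are said of these compounds alone.

Working notes on the series. All three measured compounds share one core and differ only in the group on one aromatic carbon of it. Compound 1 `CN(C)C(=O)c1cnc(C(=O)CCc2ccc(-c3ccccc3)cc2)o1` carries dimethylcarbamoyl there; in an assay for inhibition of Fatty-acid amide hydrolase 1 (Rattus norvegicus) (a lower number here means a stronger inhibitor, a higher number a weaker inhibitor), compound 1 gives 3 nM. Compound 2 `COC(=O)c1ccc(-c2cnc(C(=O)CCc3ccc(-c4ccccc4)cc3)o2)cn1` carries 6-(methoxycarbonyl)pyridin-3-yl; in this assay compound 2 gives 0.6 nM. Compound 3 `NC(=O)c1ccc(-c2cnc(C(=O)CCc3ccc(-c4ccccc4)cc3)o2)nc1` carries 5-carbamoylpyridin-2-yl; in this assay compound 3 gives 1.3 nM, the second highest of the three numbers: a 2.3-fold lower number from compound 1 to compound 3 (0.36 log units; beyond the scatter), and a 2.2-fold higher number from compound 2 to compound 3 (0.34 log units; beyond the scatter).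

Compound 4 `O=C(CCc1ccc(-c2ccccc2)cc1)c1ncc(-c2cccnc2)o1` differs from compound 3 in one place: pyridin-3-yl in place of 5-carbamoylpyridin-2-yl on an aromatic carbon. Within the data shown here, the steps that bear on this change are the two that exchanged the group on the same carbon, a 5.0-fold lower number from compound 1 to compound 2 (0.70 log units; beyond the scatter) and a 2.3-fold lower number from compound 1 to compound 3 (0.36 log units; beyond the scatter); both six-membered aromatic groups gave lower numbers than dimethylcarbamoyl, by modest amounts. Among the measured compounds shown here, no measured compound carries a six-membered aromatic group without a further substituent, so the effect of dropping the carbamoyl is not covered directly. A small step upward, near the edge of the scatter, is expected in this assay, a 1.9-fold higher number from compound 3 to compound 4 (0.28 log units; within the scatter). Compound 4 is therefore estimated at 2.5 nM, with a range of 0.8 nM to 8 nM.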

Compound 4, inhibition constant: 1.1 nM
For compound 4 the middle estimate is 2.3-fold (0.36 log units) above the measured one, and the stated range covers the measured number.
By their numbers in this assay, from the lowest: compounds 2, 4 and 3 (each within the scatter of the next, the first and the last beyond it); then compound 1.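

Among these compounds, compound 4 is the first with a six-membered aromatic group that carries no further substituent, and in this assay this plain pyridin-3-yl stands level with both substituted groups (a 1.2-fold lower number from compound 3 to compound 4 (0.07 log units; within the scatter); a 1.8-fold higher number from compound 2 to compound 4 (0.26 log units; within the scatter)). Neither the carbamoyl of compound 3 nor the methoxycarbonyl of compound 2 is therefore needed for a number of this size at this position, next to the ring oxygen of the shared core. The advantage over the dimethylcarbamoyl of compound 1 persists with the unsubstituted ring alone (a 2.7-fold lower number from compound 1 to compound 4 (0.44 log units; beyond the scatter)), and no measurement on hand accounts for any of these steps.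

The compounds shown leave open what the ring nitrogen of the pyridine contributes, as a plain phenyl at this position is not among them, and neither is a pyridin-2-yl or pyridin-4-yl without a further substituent. Also open is how far the pyridine ring tolerates other substituents, such as a carboxylic acid, an amine or a longer chain, since the two substituents shown give numbers within the scatter of compound 4.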